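A few compounds are considered here, and "the series" means these few. Any claim that something is new, unique, unknown or untested is made for them only; others in the source may bear on it.

Measured compounds:
Compound 1 `COc1ccc(S(=O)(=O)NC(=O)Nc2ccc(Cl)cc2)s1` gives 100% in a functional assay on the whole organism (6C3HED cells, Mus musculus) for inhibition, at a dose of 300 mg/kg by the oral route; a higher number here means more inhibition at the dose given (going by the name of the read-out), a lower number less inhibition.
Compound 2 `CCc1ccc(S(=O)(=O)NC(=O)Nc2ccc(Cl)cc2)o1` gives 80% in this assay.

Going by the values given here, compound 2 stands lowest of the two numbers known in this assay; its nearest neighbour, compound 1, lies a number 20 percentage points lower from compound 1 to compound 2 (beyond the scatter), a shift that exceeds the usual scatter. Among the compounds with values here, the only change between the two is the group carried by the sulfonyl sulfur, 5-ethylfuran-2-yl in compound 2 against 5-methoxythiophen-2-yl in compound 1.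

Compound 3 `CCc1ccc(S(=O)(=O)NC(=O)Nc2ccc(Cl)cc2)[nH]1` has not yet been tested. It differs from compound 2 in that same place: 5-ethyl-1H-pyrrol-2-yl in place of 5-ethylfuran-2-yl on a sulfonyl sulfur. Within the data shown here, the one step so far that bears on this site, from compound 1 to compound 2, shows that exchanging the five-membered group on the sulfonyl sulfur can move the read-out by a modest amount. With a single step to go on, and no earlier comparison of the entering group, the direction of the expected change is uncertain; compound 3 is estimated to come out at 75% (range 45% to 100%), a step of a number 5 percentage points lower from compound 2 to compound 3 (within the scatter) that may well fall within the scatter.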

Compound 3, a percentage reported as inhibition, in the whole organism at one dose (the size of the read-out at that dose, not a potency): 56%
The estimate for compound 3 lay 19 percentage points above the measured number, within the range that was stated.
By their numbers in this assay, from the lowest: compound 3; then compound 2; then compound 1.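

Going by these compounds alone, the step to the pyrrole is the first in which the ethyl group stays and only the hetero atom of the five-membered aromatic ring changes, whereas the step from compound 1 to compound 2 exchanged the ring hetero atom and the other substituent together. In this assay, there is a number 24 percentage points lower from compound 2 to compound 3 (beyond the scatter), so the exchange of 5-ethylfuran-2-yl for 5-ethyl-1H-pyrrol-2-yl on a sulfonyl sulfur is enough on its own to change the read-out, and the wider comparison gives a number 44 percentage points lower from compound 1 to compound 3 (beyond the scatter), leaving 5-methoxythiophen-2-yl with the highest number of the three groups and 5-ethyl-1H-pyrrol-2-yl with the lowest. Nothing available explains why the number falls with this exchange.

Going by these compounds, it remains open how much of the step from compound 1 to compound 2 belongs to the ring and how much to the exchange of methoxy for ethyl, a question that a 5-ethylthiophen-2-yl group on the sulfonyl sulfur would address. Also open, on these data alone, is whether the order of the three groups would hold with an amine or a carboxylic acid on the ring in place of the ethyl group.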